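The source may hold more compounds than are shown below. What is called first, only, known or untested is meant among the compounds shown, and "the series" means these compounds.

In a physicochemical assay for solubility, at pH 7 (on this read-out lower numbers stand for lower solubility and higher numbers for higher solubility), three compounds built on a shared core have been read so far. Compound 1 `CC(=O)N1CCN(C(=O)N2Cc3c(NC(=O)c4ccc(F)cc4)n[nH]c3C2(C)C)CC1` gives > 225000 nM, which is a limit of the assay and not a number. Compound 2 `CN1CCC(C(=O)N2Cc3c(NC(=O)c4ccc5ccccc5c4)n[nH]c3C2(C)C)CC1` gives a true number, 219000 nM. Compound 3 `CN1CCC(C(=O)N2Cc3c(NC(=O)c4cc(F)cc(F)c4)n[nH]c3C2(C)C)CC1` gives > 225000 nM, and this too is a limit. Compound 3 therefore stands at the limit of > 225000 nM in this assay, at which 2 of the 3 values shown sit, with no exact number of its own.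

The next compound, compound 4 `CN1CCC(C(=O)N2Cc3c(NC(=O)c4ccc(F)c(F)c4)n[nH]c3C2(C)C)CC1`, keeps the same atoms and joins them differently, with 3,4-difluorophenyl in place of 3,5-difluorophenyl on a carbonyl carbon.

Among the compounds with values here, one measured step bears on this change, since it falls on the same carbonyl carbon: an at least 1.0-fold higher number from compound 2 to compound 3 (0.01 log units; that floor lies within the scatter). That step replaces a much different group, yet what it shows does not go beyond the scatter. The present change only rearranges the same difluorophenyl group, so no shift beyond the scatter is expected in this assay, in either direction. The expected step is a number no higher from compound 3 to compound 4 (the limit leaves the size open).

For compound 4 the estimated value is 225000 nM, with an expected range from 130000 nM to 320000 nM. The assay may well report only its limit again.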

Compound 4, solubility: > 225000 nM
Compound 4: only a limit was reported (the forecaster's own chance of this, stated with the estimate: 65%); the middle value lies on the limit itself.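

Compounds 3 and 4 each carry only a limit in this assay, so the step between them cannot be read, in size or in direction. Against naphthalen-2-yl on the same carbonyl carbon, the comparison gives an at least 1.0-fold higher number from compound 2 to compound 4 (0.01 log units; that floor lies within the scatter), so 3,4-difluorophenyl, like 3,5-difluorophenyl before it, shows no step that can be placed beyond the scatter. What is new is that two arrangements of the difluorophenyl group on this carbonyl carbon now share the same reading, and with compound 1 the limit has become the usual result in this small set: the limit of > 225000 nM in this assay, at which 3 of the 4 values shown sit.

The compounds shown leave open whether any group on this carbonyl carbon would bring the reading in this assay clearly down from the limit, since the lowest true number so far, from naphthalen-2-yl, lies within the scatter of it. Going by these compounds, it also remains open what a longer chain in place of the aromatic ring, or a carboxylic acid or an amine in place of the fluorines, would do to the reading.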